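Pyridinyl for pyrazolyl in an imidazole-bearing bicyclic series

The source may report more compounds than this note shows. Statements on the series, on what has been measured and on what is new or still open speak of the compounds shown alone.

Measured compounds:
- compound 1, `COc1c(C)ccc2c1CCC2c1ncc[nH]1`: 167 nM
- compound 2, `c1cc(-c2ccn[nH]2)c2c(c1)C(c1ncc[nH]1)CC2`: 52 nM
- compound 3, `Cc1c(OCC2=NCCN2)ccc(Cl)c1NS(C)(=O)=O`: 25 nM

All three were tested in a functional assay on CHO cells for agonist activity at Alpha-1A adrenergic receptor (Homo sapiens), read by FLIPR and calcium flux; on this read-out higher numbers stand for an effect only at larger amounts of compound and lower numbers for an effect already at smaller amounts. Compound 2 gives 52 nM, the second highest of the three numbers. Compound 3, with 25 nM, sits nearest to it at a lower number, a gap that lies beyond the usual scatter. Compound 1, with 167 nM, lies furthest away at a higher number, also beyond the scatter.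

Compound 4, `c1cncc(-c2cccc3c2CCC3c2ncc[nH]2)c1`, is not yet measured. It differs from compound 2 in one place: pyridin-3-yl in place of 1H-pyrazol-5-yl on an aromatic carbon. The hydrogen-bond donor of the leaving group is lost, while one acceptor remains, and the ring grows from five to six members.

For the measured compounds named here, no measured pair shows a step of this kind, so no direct guide exists. The expectation is a moderate rise in the number, a step from compound 2 to compound 4 of a 2.1-fold higher number from compound 2 to compound 4 (0.33 log units; beyond the scatter), estimated rather than known. Compound 4 is therefore expected to give 110 nM, within a range from 35 nM to 350 nM.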

Compound 4, half-maximal effective concentration: 2060 nM
Beside the measured number, compound 4's estimate is 19-fold (1.27 log units) below it, outside the stated range (above it).
By their numbers in this assay, from the lowest: compound 3; then compound 2; then compound 1; then compound 4.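

In this assay putting pyridin-3-yl in place of 1H-pyrazol-5-yl on this aromatic carbon gives a 40-fold higher number from compound 2 to compound 4 (1.60 log units; beyond the scatter) and so counts as a large step, which shows that the effect depends strongly on which ring sits at this position of the shared core. This one change removes the hydrogen-bond donor of the leaving group, keeps one hydrogen-bond acceptor and enlarges the ring from five to six members, and a single step cannot pull these differences apart. No supporting measurement accounts for the size of this step.

The compounds shown leave open whether the lost hydrogen-bond donor or the larger ring weighs more. They also do not show how a pyrrolyl or a phenyl ring on the same aromatic carbon would behave.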